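A few compounds are considered here, and "the series" means these few. Any claim that something is new, unique, unknown or untested is made for them only; others in the source may bear on it.

Measured compounds:
compound 1 `CCCCCCCCC#Cc1cn(C/C=C\CN2C(=O)c3ccccc3C2=O)c(=O)[nH]c1=O`: 59000 nM
compound 2 `CCCCCc1ccc(C#Cc2cn(C/C=C\CN3C(=O)c4ccccc4C3=O)c(=O)[nH]c2=O)cc1`: > 100000 nM
compound 3 `O=C1c2ccccc2C(=O)N1C/C=C\Cn1cc(C#CCCc2ccccc2)c(=O)[nH]c1=O`: > 100000 nM

In a functional assay on HeLa cells (Homo sapiens) for antiproliferative activity, read by MTT assay, with a stated time of 3 days (on this read-out lower numbers stand for stronger inhibition and higher numbers for weaker inhibition), compound 1 gives 59000 nM. For compound 2 this assay reports only a limit, > 100000 nM. For compound 3 this assay also reports only a limit, > 100000 nM. Compound 3 therefore stands at a limit and not at a number, and one further value shown sits there as well (the limit of > 100000 nM in this assay, at which 2 of the 3 values shown sit). The steps read as follows: an at least 1.6-fold higher number from compound 1 to compound 2 (0.22 log units; that floor lies within the scatter); an at least 1.6-fold higher number from compound 1 to compound 3 (0.22 log units; that floor lies within the scatter); a step that the two limits leave unreadable from compound 2 to compound 3.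

Compound 4 `CCCCc1ccc(C#Cc2cn(C/C=C\CN3C(=O)c4ccccc4C3=O)c(=O)[nH]c2=O)cc1` is the next candidate: 4-butylphenyl in place of phenethyl on a triple-bonded carbon. The step that bears on it most directly, from compound 2 to compound 3, is unreadable, and compound 4 carries 4-butylphenyl on a triple-bonded carbon where compound 2 carries 4-pentylphenyl at the same place, so a limit is the most likely outcome in this assay again. No step beyond the scatter is expected in this assay; the implied step that the limit leaves unreadable from compound 3 to compound 4 is expected to lie within the scatter. Compound 4 is estimated at 120000 nM, with a range from 50000 nM to 300000 nM.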

Compound 4, half-maximal inhibitory concentration: 85000 nM
Compound 4: middle estimate off by 1.4-fold (0.15 log units), on the high side; the measured number falls inside the stated range.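

In this assay, compound 4 carries 4-butylphenyl on the triple-bonded carbon and gives a number rather than a limit, so a phenyl ring at this place does not by itself take the series to the limit. Against octyl the change reads as a 1.4-fold higher number from compound 1 to compound 4 (0.16 log units; within the scatter), which leaves 4-butylphenyl and octyl not told apart here. The readings an at least 1.1-fold lower number from compound 3 to compound 4 (0.07 log units; that floor lies within the scatter) and an at least 1.1-fold lower number from compound 2 to compound 4 (0.07 log units; that floor lies within the scatter) are floors only, so neither the change from phenethyl nor the loss of one methyl from 4-pentylphenyl has a known size, and two compounds remain at a limit: the limit of > 100000 nM in this assay, at which 2 of the 4 values shown sit.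

Going by these compounds, whether any change at this place can move the number beyond the scatter stays open. An amine or a carboxylic acid in place of the butyl chain of 4-butylphenyl would be one such test, and a chain shorter than butyl another.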